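Estimating compound 4 after losing the trifluoromethyl group

The compounds below may be only part of what the source reports. "The series", "measured", "known", "first", "only" and "open" are said of these compounds alone.

In a functional assay on SW-620 cells (Homo sapiens) for cytotoxicity, read by MTT assay, with stated times of 4 h and 72 h, tested at 2 uM (a higher number here means a weaker inhibitor, a lower number a stronger inhibitor), compound 3 `Cc1cc(Nc2ccc(C(=O)/C=C/c3ccc(C(F)(F)F)cc3)cc2)n2nc(SCc3nc4ccccc4[nH]3)nc2n1` gives 1850 nM, the highest number of the three compounds measured and so the weakest inhibitor among them. Compound 1 `COc1ccc(/C=C/C(=O)c2ccc(Nc3cc(C)nc4nc(SCc5nc6ccccc6[nH]5)nn34)cc2)cc1F` gives 140 nM, and compound 2 `COc1ccc(/C=C/C(=O)c2ccc(Nc3cc(C)nc4nc(SCc5nc6ccccc6[nH]5)nn34)cc2)cc1` gives 170 nM.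

Compound 4 `Cc1cc(Nc2ccc(C(=O)/C=C/c3cccc(F)c3)cc2)n2nc(SCc3nc4ccccc4[nH]3)nc2n1` has not yet been measured. It carries 3-fluorophenyl in place of 4-(trifluoromethyl)phenyl on a double-bonded chain carbon bound to a double-bonded chain carbon.

Among the compounds with values here, three measured steps bear on this change. Exchanging fluoro for hydrogen made no difference beyond the scatter, with a 1.2-fold higher number from compound 1 to compound 2 (0.08 log units; within the scatter). Bringing in trifluoromethyl was a different matter: the aromatic group that carries it gave a 13-fold higher number from compound 1 to compound 3 (1.12 log units; beyond the scatter), and trifluoromethyl in place of methoxy gave an 11-fold higher number from compound 2 to compound 3 (1.04 log units; beyond the scatter). Compound 4 loses the trifluoromethyl, which points to a lower number than that of compound 3. However, it has no methoxy either, and no measured compound shows what an aromatic group without both groups does, so only part of that large difference should be recovered. The expected change is a moderate one, a 3.7-fold lower number from compound 3 to compound 4 (0.57 log units; beyond the scatter). For compound 4 the estimated value is 500 nM, with an expected range from 170 nM to 1500 nM.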

Compound 4, half-maximal inhibitory concentration: 590 nM
For compound 4 the middle estimate is 1.2-fold (0.07 log units) below the measured one; measured number inside the range.
By their numbers in this assay, from the lowest: compounds 1 and 2 (each within the scatter of the next); then compound 4; then compound 3.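

In this assay the change to 3-fluorophenyl at this place on the chain gives a 3.1-fold lower number from compound 3 to compound 4 (0.50 log units; beyond the scatter) and so recovers part of the large loss seen with 4-(trifluoromethyl)phenyl. Removing trifluoromethyl therefore does not by itself restore the low numbers of the methoxy compounds: 3-fluorophenyl in place of 4-methoxyphenyl gives a 3.5-fold higher number from compound 2 to compound 4 (0.54 log units; beyond the scatter) and taking methoxy off the 3-fluoro-4-methoxyphenyl group while keeping its fluoro gives a 4.2-fold higher number from compound 1 to compound 4 (0.62 log units; beyond the scatter) in the same direction. Among these four compounds, the two aromatic groups carrying methoxy give the lowest numbers, 3-fluorophenyl comes next and 4-(trifluoromethyl)phenyl gives the highest, so a ring without either methoxy or trifluoromethyl now has a measured place in that order.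

No independent measurement is available here to explain these differences. Still open, as far as these compounds go, is how a plain phenyl group, or a phenyl group carrying an amine or a carboxylic acid, would compare at this place on the chain, and whether fluoro makes any difference on a ring that has no methoxy.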